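Adding an Imidazolylbutyl Chain to a Cytotoxic Core

The source may hold more compounds than are shown below. What is called first, only, known or untested is meant among the compounds shown, and "the series" means these compounds.

Among the measured compounds shown here, compound 1 `O=C1c2c[n+]([O-])c3ccccc3c2C(=O)c2[nH]c3ccccc3c21` stands with the highest number of the two compounds measured so far: in a toxicity assay on L02 cells (Homo sapiens) for cytotoxicity, read by MTT assay, with a stated time of 72 h (on this read-out higher numbers stand for weaker inhibition and lower numbers for stronger inhibition), compound 1 gives 400 nM. Compound 2 `CC1(C)OCC(Cn2cc(Cn3c4c(c5ccccc53)C(=O)c3c[n+]([O-])c5ccccc5c3C4=O)nn2)O1`, which carries a larger group on the same ring nitrogen, in this assay gives 120 nM, a gap beyond the usual scatter. Compound 3 `O=C1c2c[n+]([O-])c3ccccc3c2C(=O)c2c1c1ccccc1n2CCCCn1ccnc1` differs from compound 1 by 4-(1H-imidazol-1-yl)butyl in place of hydrogen on an aromatic nitrogen. For compound 3 the expected step is a 2.7-fold lower number from compound 1 to compound 3 (0.43 log units; beyond the scatter), toward a lower number, guided by compound 2 giving 120 nM with a group on that nitrogen. Compound 3 is therefore estimated at 150 nM, within a range from 50 nM to 500 nM.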

Compound 3, half-maximal inhibitory concentration: 150 nM
Beside the measured number, compound 3's estimate shows no gap at the digits printed, within the range that was stated.
By their numbers in this assay, from the lowest: compounds 2 and 3 (each within the scatter of the next); then compound 1.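

Among the compounds shown here, compound 3 gives the first reading of a single change on this aromatic nitrogen: in this assay, 4-(1H-imidazol-1-yl)butyl in place of hydrogen brings a 2.7-fold lower number from compound 1 to compound 3 (0.43 log units; beyond the scatter). The hydrogen on this nitrogen is therefore not required for inhibition on this read-out. Nothing shown here explains the step.

The compounds shown leave open whether the length of the butyl chain matters, which a propyl or hexyl chain could test. They also leave open whether the imidazole ring itself counts, which a dimethylamino or morpholine group in its place could test.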